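This account rests on a few compounds, and the source may have more. Where it says the series, first, only, none or still open, it means among the compounds named here.

Measured so far:
compound 1 `CCC=C(c1cc(OC)cc(OC)c1)c1ccc(OC)c(OC)c1`: > 10000 nM (a limit, not a number)
compound 2 `COc1cc(OC)cc(/C(=C/C#N)c2ccc(OC)c(OC)c2)c1`: 110 nM
compound 3 `COc1ccc(C(=CC#N)c2ccc(OC)c(OC)c2)cc1OC`: 140 nM

All three were read in a functional assay on HCT-116 cells (Homo sapiens) for cytotoxicity, read by scintillation counting and thymidine incorporation, with a stated time of 72 h; a lower number here means a stronger inhibitor, a higher number a weaker inhibitor. Compound 1 stands at the limit of > 10000 nM in this assay, at which 1 of the 3 values shown sits, so it offers no number to step from. Compound 2 gives 110 nM and compound 3 gives 140 nM, two values within the scatter of each other.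

Still unmeasured is compound 4 `COC=C(c1cc(OC)cc(OC)c1)c1ccc(OC)c(OC)c1`. It differs from compound 1 by methoxy in place of ethyl on a double-bonded chain carbon bound to a double-bonded chain carbon, with methoxy in place of ethyl on a double-bonded chain carbon bound to a double-bonded chain carbon. Among the measured compounds shown here, no measured pair shows this change. Compound 2 at 110 nM shows only that the series can reach strong inhibition, so a moderate gain in this assay is expected, and the expected step is an at least 2.5-fold lower number from compound 1 to compound 4 (0.39 log units; beyond the scatter). A further limit reading remains quite possible. For compound 4 the estimate is 4000 nM, with an expected range of 400 nM to 20000 nM.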

Compound 4, half-maximal inhibitory concentration: > 10000 nM
Compound 4: only a limit was reported; the forecaster's own chance of this, stated with the estimate: 40%; middle value at least 2.5-fold (0.39 log units) away from the limit.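

In this assay, compound 1 and compound 4 both give a limit rather than a number, so no step can be read between them: the limit of > 10000 nM in this assay, at which 2 of the 4 values shown sit.

From the compounds shown here alone, whether methoxy in place of ethyl changes inhibition at all stays open.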